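The source may report more compounds than this note shows. Statements on the series, on what has been measured and on what is new or still open speak of the compounds shown alone.

Compound 1 `CC(C)=CCC/C(C)=C/COc1cc(=O)n(CCCO)c2c1CC(C/C=C(\C)CCC=C(C)C)C(C)(C)C2`: 15.8%
Compound 2 `CC(C)=CCC/C(C)=C/CC1Cc2c(OCCCNC(=O)c3ccco3)cc(=O)n(CCCO)c2CC1(C)C`: 69.5%
Compound 3 `CC(C)=CCC/C(C)=C/CC1Cc2c(OC(=O)Nc3ccccc3F)cc(=O)n(CCCO)c2CC1(C)C`: 71.6%

In a functional assay on PANC-1 cells (Homo sapiens) for inhibition, read by MTT assay, with a stated time of 24 h, tested at 10 uM (on this read-out lower numbers stand for less inhibition and higher numbers for more inhibition at the one concentration tested (going by the name of the read-out)), compound 3 stands at the top of the three numbers, but the step of a number 2.1 percentage points higher from compound 2 to compound 3 (within the scatter) is within the usual scatter, so the two cannot be ordered; only compound 1 sits clearly apart, with a number 55.8 percentage points higher from compound 1 to compound 3 (beyond the scatter).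

Compound 4 `CC(C)=CCC/C(C)=C/CC1Cc2c(OC(=O)Nc3ccc(F)cc3F)cc(=O)n(CCCO)c2CC1(C)C` is the next compound to be measured in this assay . It differs from compound 3 by fluoro in place of hydrogen on an aromatic carbon.

Of the measured steps, two are large: a number 53.7 percentage points higher from compound 1 to compound 2 (beyond the scatter) and a number 55.8 percentage points higher from compound 1 to compound 3 (beyond the scatter). Both replace a long chain on the oxygen of the core with a smaller amide- or carbamate-bearing group, a change of a different kind from adding a single fluoro to an aromatic ring. The remaining step, a number 2.1 percentage points higher from compound 2 to compound 3 (within the scatter), swaps one such side group for another and stays within the scatter. None of the three steps touches the fluorophenyl ring itself, so the data give no direct guide for the change to compound 4.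

On that basis compound 4 is expected to stay close to compound 3, with a step of a number 1.6 percentage points lower from compound 3 to compound 4 (within the scatter), not beyond the scatter. The estimate for compound 4 in this assay is 70%, with a range from 55% to 85%.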

Compound 4, a percentage reported as inhibition, at one concentration (the size of the read-out at that concentration, not a potency): 33.7%
For compound 4 the middle estimate is 36.3 percentage points above the measured one; measured number outside the range, below it.
By their numbers in this assay, from the lowest: compound 1; then compound 4; then compounds 2 and 3 (each within the scatter of the next).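

In this assay, adding one fluoro to the ring of compound 3, on the aromatic carbon para to a large group and meta to the existing fluoro group, proves far from a silent change, giving a number 37.9 percentage points lower from compound 3 to compound 4 (beyond the scatter). The earlier near-equality of compounds 2 and 3 might have suggested that replacing the long chain on the oxygen was enough to hold the number up, but compound 4 goes against that reading: the (2,4-difluorophenyl)carbamoyl group gives a number 35.8 percentage points lower from compound 2 to compound 4 (beyond the scatter), while still leaving a number 17.9 percentage points higher from compound 1 to compound 4 (beyond the scatter), so the substitution on this ring decides much of what the carbamoyl side group delivers. Nothing available accounts for why one fluoro at this place has a step of this size.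

The compounds shown leave open whether this drop belongs to fluoro in particular or to any substituent at this place, a question that a chloro, methyl or methoxy group there would address. They also do not say whether a lone fluoro at this place, without the 2-fluoro group, would give the same drop, and a single concentration gives no potency for any of the compounds.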